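Taking the methyl group off compound 3

The compounds below may be only part of what the source reports. "The series", "measured", "known", "first", "only" and "open" are said of these compounds alone.

Measured so far:
- Compound 1 `Brc1ccc(NCc2cn(-c3ccccc3)nc2-c2ccccc2)cc1`: > 100000 nM
- Compound 2 `Clc1ccc(NCc2cn(-c3ccccc3)nc2-c2ccc(Cl)cc2)cc1`: 73000 nM
- Compound 3 `Cc1ccc(-c2nn(-c3ccccc3)cc2CNc2ccc(Cl)cc2)cc1`: > 100000 nM

In an ADME assay on BHK-21 cells (Mesocricetus auratus) for cytotoxicity, read by MTT assay, with a stated time of 72 h (on this read-out lower numbers stand for higher toxicity in this test and higher numbers for lower toxicity in this test), compound 3 gives > 100000 nM, which is a limit of the assay and not a number. Compound 1 gives > 100000 nM, which is also a limit. Compound 3 therefore shares (the limit of > 100000 nM in this assay, at which 2 of the 3 values shown sit), and compound 2 alone has a numerical value.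

Compound 4 `Clc1ccc(NCc2cn(-c3ccccc3)nc2-c2ccccc2)cc1` is still to be measured. It arises from compound 3 through one change hydrogen in place of methyl on an aromatic carbon, para to a large group, so that 4-methylphenyl becomes phenyl.

One measured step involves the same methyl group: an at least 1.3-fold higher number from compound 2 to compound 3 (0.13 log units; that floor lies within the scatter). That step ends on a limit and fixes only a floor, so it gives no firm size. On this evidence, no change beyond the scatter is expected in either direction in this assay, and another limit is quite possible. The expected step is a number no higher from compound 3 to compound 4 (the limit leaves the size open). For compound 4 the estimate is 100000 nM, with an expected range from 55000 nM to 180000 nM.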

Compound 4, half-maximal cytotoxic concentration: > 100000 nM
Compound 4: only a limit was reported (the forecaster's own chance of this, stated with the estimate: 60%); the middle value sits exactly at the limit.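

In this assay compound 4 gives > 100000 nM, which is a limit of the assay and not a number, so phenyl now sits at the same limit as 4-methylphenyl: the limit of > 100000 nM in this assay, at which 3 of the 4 values shown sit.

Hydrogen in place of chloro on this aromatic carbon gives an at least 1.3-fold higher number from compound 2 to compound 4 (0.13 log units; that floor lies within the scatter), so this first direct comparison of hydrogen with chloro at this place shows no difference beyond the scatter. The steps to compound 4 from compound 3 and from compound 1 cannot be read, as both ends of each are limits.

The compounds shown leave open whether a carboxylic acid, an amine or a longer chain at this place would give a number in this assay. They also leave open how far any of the three compounds at the limit lies from the numerical value of compound 2.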